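Aryl exchange from compound 3 to compound 4

This account rests on a few compounds, and the source may have more. Where it says the series, first, only, none or still open, it means among the compounds named here.

In a functional assay on PC-3 cells (Homo sapiens) for cytotoxicity, read by MTT assay, with a stated time of 72 h (on this read-out higher numbers stand for weaker inhibition and lower numbers for stronger inhibition), compound 1 (`CNC(=O)c1cc(Oc2ccc(C3=NNC(c4cccc([N+](=O)[O-])c4)C3)cc2)ccn1`) stands as "not determined" (no result reported). Compound 2 (`CNC(=O)c1cc(Oc2ccc(C3CC(c4ccc(Br)cc4)=NN3)cc2)ccn1`) also stands as "not determined" (no result reported). Compound 3 (`CNC(=O)c1cc(Oc2ccc(C3=NN(C(N)=S)C(c4cccc([N+](=O)[O-])c4)C3)cc2)ccn1`) gives > 50000 nM, which is a limit of the assay and not a number. The series therefore offers no single number, only (the limit of > 50000 nM in this assay, at which 1 of the 3 values shown sits). Compound 4 (`CNC(=O)c1cc(Oc2ccc(C3=NN(C(N)=S)C(c4cccc(Cl)c4Cl)C3)cc2)ccn1`) carries 2,3-dichlorophenyl in place of 3-nitrophenyl on a saturated ring carbon. For the measured compounds named here, no measured step sizes this change, so only a small shift towards stronger inhibition is expected in this assay, and a result at the limit would be no surprise. The estimated at least 1.6-fold lower number from compound 3 to compound 4 (0.22 log units; that floor lies within the scatter) is modest. Compound 4 is estimated at 30000 nM, with an expected range of 10000 nM to 50000 nM.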

Compound 4, half-maximal inhibitory concentration: 15900 nM
The estimate for compound 4 lay 1.9-fold (0.28 log units) above the measured number; measured number inside the range.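

For the compounds shown here, on the saturated ring carbon, the aryl group has a readable effect in this assay: compound 4 gives 15900 nM, the only single number. With 2,3-dichlorophenyl in place of 3-nitrophenyl, the change is an at least 3.1-fold lower number from compound 3 to compound 4 (0.49 log units; beyond the scatter), so this position responds to the aryl exchange. That size is only a floor, as compound 3 stands at a limit of the assay and not at a number: the limit of > 50000 nM in this assay, at which 1 of the 4 values shown sits.

Open, going by these compounds, is how a phenyl ring with a single chlorine would compare with compound 4. Also open, on these data alone, is whether an aminophenyl or a pyridine ring on this carbon would move the number further.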